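The compounds below may be only part of what the source reports. "The series", "measured", "known", "first", "only" and "open" are said of these compounds alone.

Within the data shown here, compound 2 `COc1ccc(COc2ccc(-c3cc(CN4CCN(Cc5ccc(C(F)(F)F)cc5)CC4)no3)cc2)cc1` is one of two compounds measured in a functional assay on Mahlavu cells (Homo sapiens) for antiproliferative activity, read by sulforhodamine B assay, with a stated time of 72 h; a higher number here means a weaker inhibitor, a lower number a stronger inhibitor; there compound 2 gives 4900 nM, the higher of the two numbers. Among the measured compounds shown here, its only neighbour, compound 1 `Fc1cccc(COc2ccc(-c3cc(CN4CCN(Cc5ccc(C(F)(F)F)cc5)CC4)no3)cc2)c1`, gives 2900 nM in this assay, and the two numbers lie within the scatter of each other, as the step of a 1.7-fold higher number from compound 1 to compound 2 (0.23 log units; within the scatter) shows. Compound 3 `COc1cc(COc2ccc(-c3cc(CN4CCN(Cc5ccc(C(F)(F)F)cc5)CC4)no3)cc2)cc(OC)c1` has not yet been measured. It differs from compound 2 in one place: 3,5-dimethoxyphenyl in place of 4-methoxyphenyl on a saturated chain carbon bound to an oxygen on an aromatic ring. For the measured compounds named here, only the step from compound 1 to compound 2 bears on this change, since it alters the same group at the same place, and that step stayed within the scatter. On that single comparison, the step in this assay from compound 2 to compound 3 is expected to be no larger than the scatter, with no clear direction: no change at the digits printed from compound 2 to compound 3 (within the scatter). The value of compound 3 in this assay is therefore estimated at 4900 nM, with a likely range from 2000 nM to 12000 nM.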

Compound 3, half-maximal inhibitory concentration: 4300 nM
The estimate for compound 3 lay 1.1-fold (0.06 log units) above the measured number, within the range that was stated.
By their numbers in this assay, from the lowest: compounds 1, 3 and 2 (each within the scatter of the next).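

In this assay, a third group on the saturated chain carbon bound to an oxygen on an aromatic ring again leaves the number within the scatter, with a 1.1-fold lower number from compound 2 to compound 3 (0.06 log units; within the scatter) and a 1.5-fold higher number from compound 1 to compound 3 (0.17 log units; within the scatter) as the new steps. The earlier pair compared only 3-fluorophenyl and 4-methoxyphenyl; now 3,5-dimethoxyphenyl, with 10 heavy atoms against 8 and 2 hydrogen-bond acceptors against 1 in 4-methoxyphenyl, also gives no separable difference, so these three groups cannot be ranked in this assay. No measurement at hand bears on why the numbers stay this close.

From the compounds shown here alone, all three compounds carry a substituted phenyl at this place, so it remains open whether an amine, a carboxylic acid or a longer chain there would give a step beyond the scatter. The compounds shown also leave open how changes elsewhere in the shared core would read, since all three keep it unchanged.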